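Replacing a hydroxyl with an amine on a lipidic aminoglycoside tail

A few compounds are considered here, and "the series" means these few. Any claim that something is new, unique, unknown or untested is made for them only; others in the source may bear on it.

In a toxicity assay on the whole organism (J774 cells) for cytotoxicity, with Mus musculus as the target, read by MTT assay, with a stated time of 24 h, tested at 10 uM (on this read-out higher numbers stand for a weaker effect at the one concentration tested and lower numbers for a stronger effect), compound 1 `CCCCCCCCCO[C@@H]1[C@@H](N)[C@@H](OCC(O)CO)O[C@H](CN)[C@H]1OCCCCCCCCC` gives 89.7%. Among the measured compounds shown here, only one other compound has been measured against it: compound 2 `C=CCO[C@H]1O[C@H](CN)[C@@H](O)[C@H](O)[C@H]1N`, which in this assay gives 82.2%. The two numbers stand close together, the gap between them within the usual scatter, so nothing more than that can be said of how compound 1 compares with compound 2 on this read-out.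

Compound 3 `CCCCCCCCCO[C@@H]1[C@@H](N)[C@@H](OC[C@@H](O)CN)O[C@H](CN)[C@H]1OCCCCCCCCC` has not yet been measured. It differs from compound 1 in a single place: 2-amino-1-hydroxyethyl in place of 1,2-dihydroxyethyl on a saturated chain carbon bound to an oxygen on a saturated carbon. For the measured compounds named here, no step between measured compounds is available for this kind of change, so the expectation rests on the two numbers alone and on the smallness of the change, which keeps the count of heavy atoms, donors and acceptors unchanged.

On that basis compound 3 is expected to stay near compound 1, with a step from compound 1 to compound 3 of about a number 4.7 percentage points lower from compound 1 to compound 3 (within the scatter) in this assay, probably not beyond the scatter. Compound 3 is estimated at 85%, within a range from 65% to 100%.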

Compound 3, a percentage reported as activity, at one concentration (the size of the read-out at that concentration, not a potency): 85.1%
Beside the measured number, compound 3's estimate is 0.1 percentage points below it; low and high end bracket the measured number.
By their numbers in this assay, from the lowest: compounds 2, 3 and 1 (each within the scatter of the next).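

Among the compounds shown here, at this place, on a saturated chain carbon bound to an oxygen on a saturated carbon, 2-amino-1-hydroxyethyl in place of 1,2-dihydroxyethyl gives a number 4.6 percentage points lower from compound 1 to compound 3 (within the scatter) in this assay, and this is the only single-place step the compounds offer. The earlier pair differed in more than one place and could not speak to any one group, whereas this step shows that, at the one concentration tested, the read-out does not separate these two groups at this position, so an amine can stand here in place of a hydroxyl without a difference beyond the scatter. No measurement shown bears on why the two groups read alike.

From the compounds shown here alone, whether other groups at the same place, such as a carboxylic acid, a guanidine or a longer chain ending in an amine, would also leave this assay within the scatter of compound 1 remains open. Also open, going by these compounds, are the other arrangement of the defined stereocentre in 2-amino-1-hydroxyethyl and the behaviour of compound 3 at any other concentration.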